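Removing the Para Ethoxy Group from a Triazole Thiol Series

The source may hold more compounds than are shown below. What is called first, only, known or untested is meant among the compounds shown, and "the series" means these compounds.

Compound 3 `CCOc1ccc(-n2c(S)nnc2Sc2nnc(-c3ccccc3)n2-c2ccccc2)cc1` shows the lowest of the two numbers available in a functional assay on MDA-MB-231 cells (Homo sapiens) for inhibition, read by MTT assay, with a stated time of 48 h; a higher number here means a weaker inhibitor, a lower number a stronger inhibitor; compound 3 gives 43900 nM. Its nearest neighbour is compound 2 `Sc1nnc(Sc2nnc(-c3ccccc3)n2-c2ccccc2)n1-c1ccc(Cl)cc1`, which in this assay gives 49700 nM, and the step of a 1.1-fold lower number from compound 2 to compound 3 (0.05 log units; within the scatter) lies within the scatter. Compound 1 `COc1ccc(-n2c(S)nnc2Sc2nnc(-c3ccccc3)n2-c2ccccc2)cc1` carries a methoxy group in the same position, and in this assay compound 1 gives "not determined" (no result reported). Compound 4 `Sc1nnc(Sc2nnc(-c3ccccc3)n2-c2ccccc2)n1-c1ccccc1` differs from compound 3 by hydrogen in place of ethoxy on an aromatic carbon. For the measured compounds named here, only the step from compound 2 to compound 3 bears on this change, and it was flat, so no shift beyond the scatter is expected: the estimated step is a 1.1-fold higher number from compound 3 to compound 4 (0.06 log units; within the scatter). Compound 4 is therefore expected to give 50000 nM, within a range of 20000 nM to 120000 nM.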

Compound 4, half-maximal inhibitory concentration: 34600 nM
Estimate against measurement, compound 4: 1.4-fold (0.16 log units) above; the measured number falls inside the stated range.
By their numbers in this assay, from the lowest: compounds 4, 3 and 2 (each within the scatter of the next).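

With hydrogen on this aromatic carbon, para to a large group, the series now has an unsubstituted reference. In this assay the data give a 1.3-fold lower number from compound 3 to compound 4 (0.10 log units; within the scatter) and a 1.4-fold lower number from compound 2 to compound 4 (0.16 log units; within the scatter), so neither ethoxy nor chloro is separated from hydrogen beyond the scatter at this position.

From the compounds shown here alone, whether an amine, a carboxylic acid or a longer alkoxy chain here would give a similarly flat result remains open. Compound 1, with its methoxy group, adds no number to the comparison. Nothing available bears on why these values lie so close.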